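Ether-linked heteroaryl variation on the dichlorophenylpiperazine amide

The source may hold more compounds than are shown below. What is called first, only, known or untested is meant among the compounds shown, and "the series" means these compounds.

Measured so far:
compound 1 `O=C(COCc1cscn1)N1CCN(c2ccc(Cl)cc2Cl)CC1`: 290 nM
compound 2 `O=C(COCc1nccs1)N1CCN(c2ccc(Cl)cc2Cl)CC1`: 10300 nM

In a functional assay on HEK293 cells for positive allosteric modulation of metabotropic glutamate receptor 5 (Homo sapiens), read by FLIPR and calcium flux (a lower number here means that less compound is needed, a higher number that more compound is needed for the effect), compound 2 gives the higher of the two numbers, so more of it is needed than of compound 1. Going by the values given here, the single step covered so far, a 36-fold higher number from compound 1 to compound 2 (1.55 log units; beyond the scatter), moves the attachment point of the same ring and shows that a small change at this position can shift the number strongly.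

Compound 3 `N#Cc1ccc(COCC(=O)N2CCN(c3ccc(Cl)cc3Cl)CC2)s1` is the next candidate. It differs from compound 2 by 5-cyanothiophen-2-yl in place of 1,3-thiazol-2-yl on a saturated chain carbon bound to an oxygen on a saturated carbon. Among the compounds with values here, no measured step exchanges the thiazole for a thiophene or introduces a nitrile, so the direction of the change cannot be read from the data; the step from compound 1 to compound 2 only warns that the size may be large.

For compound 3 the expected value in this assay is 4000 nM, within 700 nM to 20000 nM. The estimated step is a 2.6-fold lower number from compound 2 to compound 3 (0.41 log units; beyond the scatter).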

Compound 3, half-maximal effective concentration: 210 nM
The estimate for compound 3 lay 19-fold (1.28 log units) above the measured number; measured number outside the range, below it.
By their numbers in this assay, from the lowest: compounds 3 and 1 (each within the scatter of the next); then compound 2.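

The step of a 49-fold lower number from compound 2 to compound 3 (1.69 log units; beyond the scatter) shows that a low number in this assay is not tied to the 1,3-thiazol-4-yl group, since a ring with one hetero atom and a nitrile reaches the same range on the same saturated chain carbon. The step of a 1.4-fold lower number from compound 1 to compound 3 (0.14 log units; within the scatter) lies within the scatter, so these two compounds cannot be told apart, and among the three only compound 2 stands apart, with the 1,3-thiazol-2-yl group. Nothing available explains why this group differs from the other two.

Going by these compounds, the 5-cyanothiophen-2-yl group changes the ring and adds the nitrile in one step, so the share of each remains open. A plain thiophen-2-yl group would separate the two, and an aminomethyl or carboxylic acid group in place of the nitrile would test how much that substituent matters.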